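The source may report more compounds than this note shows. Statements on the series, on what has been measured and on what is new or still open speak of the compounds shown alone.

Compound 1, `CSc1nc(-c2ccccc2)c(C#N)c(N2CCN(c3ccnc4cc(Cl)ccc34)CC2)n1`, gives in an ADME assay on Vero cells (Chlorocebus sabaeus) for cytotoxicity, read by microscopy (on this read-out higher numbers stand for lower toxicity in this test and lower numbers for higher toxicity in this test), no number but a limit, > 100000 nM, which sets (the limit of > 100000 nM in this assay, at which 1 of the 2 values shown sits). Among the measured compounds shown here, compound 2, `CSc1nc(NCCCCNc2ccnc3cc(Cl)ccc23)c(C#N)c(-c2ccc([N+](=O)[O-])cc2)n1`, is the only compound with a full number in this assay and gives 4000 nM. Compound 3, `COc1cc(-c2nc(SC)nc(NCCCCNc3ccnc4cc(Cl)ccc34)c2C#N)cc(OC)c1OC`, differs from compound 2 by 3,4,5-trimethoxyphenyl in place of 4-nitrophenyl on an aromatic carbon. For the measured compounds named here, no step between two measured compounds is available to size this change. The step from compound 2 to compound 3 is expected to stay within the usual scatter, estimated as a 1.3-fold lower number from compound 2 to compound 3 (0.12 log units; within the scatter). Compound 3 is accordingly estimated at 3000 nM, with a range from 800 nM to 12000 nM.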

Compound 3, minimum cytotoxic concentration: 4000 nM
Compound 3: the middle estimate sits 1.3-fold (0.12 log units) below what was measured, and the stated range covers the measured number.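

The exchange of 4-nitrophenyl for 3,4,5-trimethoxyphenyl on this aromatic carbon, ortho to a cyano group, gives in this assay no change at the digits printed from compound 2 to compound 3 (within the scatter). Among the compounds shown here, this is the first measured step at this position, and it shows that these two substituted phenyl groups can replace each other with no reading beyond the scatter. No measured property in these notes bears on this step.

Open, as far as these compounds go, is how an amine or a carboxylic acid on this carbon would read in this assay. Also open, from the compounds shown here alone, is whether a small alkyl group in place of the aromatic ring would keep the reading of compound 3.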